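Isatin-type series: benzylic aryl substitution at the ring nitrogen

A few compounds are considered here, and "the series" means these few. Any claim that something is new, unique, unknown or untested is made for them only; others in the source may bear on it.

Measured so far:
- compound 1 `CCN1C(=O)C(=O)c2cc(-c3ccc(OC)cc3)ccc21`: 2200 nM in a functional assay on K562 cells (Homo sapiens) for antiproliferative activity, read by MTT assay, with a stated time of 48 h; a higher number here means a weaker inhibitor, a lower number a stronger inhibitor
- compound 2 `COc1ccc(-c2ccc3c(c2)C(=O)C(=O)N3Cc2ccc(F)cc2)cc1`: 560 nM in this assay

Compound 1 gives the highest number of the two in this assay; its nearest neighbour is compound 2, reached by a 3.9-fold lower number from compound 1 to compound 2 (0.59 log units; beyond the scatter), a modest step beyond the scatter, brought about by 4-fluorophenyl in place of methyl on a saturated chain carbon bound to an amide-type nitrogen in a ring.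

Compound 3 `COc1ccc(-c2ccc3c(c2)C(=O)C(=O)N3Cc2ccc(OC)c(OC)c2)cc1` is not yet measured. It differs from compound 1 by 3,4-dimethoxyphenyl in place of methyl on a saturated chain carbon bound to an amide-type nitrogen in a ring

Among the measured compounds shown here, the only step that bears on this change is the one from compound 1 to compound 2, where an aryl group entered at the same place and the number fell by a 3.9-fold lower number from compound 1 to compound 2 (0.59 log units; beyond the scatter). For the measured compounds named here, a second aryl group at the same place is therefore expected to move this assay downward by a similar modest amount, though the two acceptors of 3,4-dimethoxyphenyl have no precedent among the measured compounds. Compound 3 is estimated at 650 nM, range 250 nM to 1800 nM, corresponding to an expected step of a 3.4-fold lower number from compound 1 to compound 3 (0.53 log units; beyond the scatter).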

Compound 3, half-maximal inhibitory concentration: 60 nM
The estimate for compound 3 lay 11-fold (1.03 log units) above the measured number; the whole stated range lies above it.
By their numbers in this assay, from the lowest: compound 3; then compound 2; then compound 1.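

At the place on a saturated chain carbon bound to an amide-type nitrogen in a ring, the identity of the aryl group matters in this assay, not merely its presence. Replacing methyl with 3,4-dimethoxyphenyl gives a 37-fold lower number from compound 1 to compound 3 (1.56 log units; beyond the scatter), and exchanging only 4-fluorophenyl for 3,4-dimethoxyphenyl still gives a 9.3-fold lower number from compound 2 to compound 3 (0.97 log units; beyond the scatter), making compound 3 the most potent of the three in this read-out. No available evidence accounts for the gain.

Whether the gain requires both methoxy groups remains open, since no compound shown carries just one of them at this place. On these data alone, how an unsubstituted phenyl, a hydroxy group or a dimethylamino group would read here in this assay also remains open.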